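A few compounds are considered here, and "the series" means these few. Any claim that something is new, unique, unknown or untested is made for them only; others in the source may bear on it.

Compound 2, `CO/N=c1\[nH]cnc2c1[n+](C/C=C(\C)CC/C=C(\C)CC/C=C(\C)CCC=C(C)C)cn2CCC#N`, carries a methoxy on its oxime and a cyanoethyl on the core; in a functional assay on ACHN cells (Homo sapiens) for cytotoxicity (a higher number here means a weaker inhibitor, a lower number a stronger inhibitor), compound 2 gives 11400 nM. Compound 1, `CC(C)=CCC/C(C)=C/CC/C(C)=C/CC/C(C)=C/C[n+]1cn(C)c2nc[nH]/c(=N\OCc3ccccc3)c21`, has a benzyloxy on the oxime and a methyl on the core, and in this assay compound 1 gives 20900 nM. Of the two numbers that of compound 2 is the lower, yet the gap to compound 1 lies within the scatter of repeated measurements, so no order between the two can be claimed. Among the measured compounds shown here, compound 1 and compound 2 differ in two places at once, so their pair gives no isolated step.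

Compound 3, `CC(C)=CCC/C(C)=C/CC/C(C)=C/CC/C(C)=C/C[n+]1cn(CCC#N)c2nc[nH]/c(=N\OCc3ccccc3)c21`, arises from compound 2 by phenyl in place of hydrogen on a saturated chain carbon bound to an oxygen — phenyl in place of hydrogen on a saturated chain carbon bound to an oxygen, or, cut one bond further out, methyl to benzyl, methoxy to benzyloxy. The same benzyloxy group is present in compound 1, whose value sits within the scatter of compound 2. No step beyond the scatter is therefore expected in this assay in either direction. The estimate for compound 3 in this assay is 15000 nM, with a range from 5000 nM to 45000 nM, which corresponds to an expected 1.3-fold higher number from compound 2 to compound 3 (0.12 log units; within the scatter).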

Compound 3, half-maximal inhibitory concentration: 38900 nM
Beside the measured number, compound 3's estimate is 2.6-fold (0.41 log units) below it; measured number inside the range.
By their numbers in this assay, from the lowest: compounds 2, 1 and 3 (each within the scatter of the next, the first and the last beyond it).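

Methyl to benzyl, methoxy to benzyloxy, with the cyanoethyl held on the core, gives the first step beyond the scatter at this position: in this assay the change amounts to a 3.4-fold higher number from compound 2 to compound 3 (0.53 log units; beyond the scatter), a modest weakening. The other single change, cyanomethyl in place of hydrogen on a saturated chain carbon bound to an aromatic nitrogen, with the benzyloxy held on the oxime, gives a 1.9-fold higher number from compound 1 to compound 3 (0.27 log units; within the scatter), so no effect of that change can be claimed in this assay. The data at hand offer no explanation for the weakening that follows the entry of the phenyl.

As far as these compounds go, the effect of the phenyl rests on this one pair, and it remains open whether the same change would give a similar step with a methyl on the core. Also open, from the compounds shown here alone, is how the oxime would fare with a free hydroxyl or an ethoxy in place of the methoxy, or with an amine or a carboxylic acid on the phenyl ring of the benzyloxy.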